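This account rests on a few compounds, and the source may have more. Where it says the series, first, only, none or still open, it means among the compounds named here.

Compound 1, `CCCCCc1cc2cn([C@H]3C[C@H](O)[C@@H](CO)O3)c(=O)nc2o1`, in a functional assay on HEL cells (Homo sapiens) for cytotoxicity, read by microscopy (on this read-out higher numbers stand for lower toxicity in this test and lower numbers for higher toxicity in this test), gives > 50000 nM, a limit of the assay and not a number.
Compound 2, `CCCCCCc1cc2cn([C@H]3C[C@H](O)[C@@H](CO)O3)c(=O)nc2o1`, in this assay gives > 50000 nM, a limit of the assay and not a number.
Compound 3, `CCCCCCCCCCc1cc2cn([C@H]3C[C@H](O)[C@@H](CO)O3)c(=O)nc2o1`, in this assay gives > 50000 nM, a limit of the assay and not a number.

Compound 3 stands where the other two stand: all three values sit at the limit (the limit of > 50000 nM in this assay, at which 3 of the 3 values shown sit), so no number separates compound 3 from compound 1 or compound 2 on what has been measured.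

Compound 4, `C=CCCCc1cc2cn([C@H]3C[C@H](O)[C@@H](CO)O3)c(=O)nc2o1`, is not yet measured. It differs from compound 3 by vinyl in place of heptyl on a saturated chain carbon, three bonds along the chain from an aromatic carbon. Three measured steps alter the same chain, and none of them can be read: a step that the two limits leave unreadable from compound 1 to compound 2, a step that the two limits leave unreadable from compound 1 to compound 3 and a step that the two limits leave unreadable from compound 2 to compound 3. Each joins two limits, so the size of the step that a change of this chain makes in this assay is not known from these compounds. For compound 4 the expectation is therefore the same outcome, a limit rather than a number, with the expected step of a number no higher from compound 3 to compound 4 (the limit leaves the size open) being no move beyond the scatter. Compound 4 is estimated at 50000 nM, in the range 25000 nM to 100000 nM, and the assay is expected most likely to report only its limit again.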

Compound 4, minimum cytotoxic concentration: > 200000 nM
Compound 4 was reported as a limit; the forecaster's own chance of this, stated with the estimate: 85%; at least 4.0-fold (0.60 log units) between middle value and limit.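

In this assay compound 4 gives > 200000 nM, a limit of the assay and not a number. Going by these compounds alone, compound 1, compound 2 and compound 3 also sit at limits, so no step from any of them to compound 4 can be read. The compounds shown leave open whether changing this chain alters toxicity in this assay at all, and by how much.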